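Ethoxy for (2-hydroxyethyl)amino on a carbonyl carbon

The source may report more compounds than this note shows. Statements on the series, on what has been measured and on what is new or still open speak of the compounds shown alone.

In a functional assay on HCT-116 cells (Homo sapiens) (a lower number here means a stronger inhibitor, a higher number a weaker inhibitor), compound 1 `COc1cc(NC(C)CCCNC(=O)NCCO)c2ncccc2c1` gives > 100000 nM, which is a limit and not a number. Compound 3 `COc1cc(NC(C)CCCNC(=O)N(CCO)CCO)c2ncccc2c1` gives > 100000 nM, which is also a limit. Compound 2 `COc1cc(NC(C)CCCNC(=O)NOCc2ccccc2)c2ncccc2c1` alone gives a number, 14000 nM. Compound 4 `CCOC(=O)NCCCC(C)Nc1cc(OC)cc2cccnc12` carries ethoxy in place of (2-hydroxyethyl)amino on a carbonyl carbon. Within the data shown here, no measured step makes this exact change. The closest guides are an at least 7.1-fold lower number from compound 1 to compound 2 (0.85 log units; beyond the scatter) and an at least 7.1-fold higher number from compound 2 to compound 3 (0.85 log units; beyond the scatter), while a step that the two limits leave unreadable from compound 1 to compound 3 adds little. Both readable steps involve benzyloxy, and the ethoxy of compound 4 has no ring, so a smaller gain is expected, a lower number with an at least 2.5-fold lower number from compound 1 to compound 4 (0.39 log units; beyond the scatter). Compound 4 is estimated at 40000 nM, with an expected range from 12000 nM to 100000 nM.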

Compound 4, half-maximal inhibitory concentration: 28000 nM
Compound 4: the middle estimate sits 1.4-fold (0.15 log units) above what was measured, within the range that was stated.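

On this carbonyl carbon, ethoxy in place of (2-hydroxyethyl)amino gives an at least 3.5-fold lower number from compound 1 to compound 4 (0.55 log units; beyond the scatter), and ethoxy in place of bis(2-hydroxyethyl)amino gives an at least 3.5-fold lower number from compound 3 to compound 4 (0.55 log units; beyond the scatter), so in this assay a readable value does not depend on a benzyloxy ring. Against (benzyloxy)amino, ethoxy gives a 2.0-fold higher number from compound 2 to compound 4 (0.30 log units; within the scatter), so the two cannot be ordered. The first two steps rest on limits, not numbers: the limit of > 100000 nM in this assay, at which 2 of the 4 values shown sit.

On these data alone, whether the lower numbers follow from losing the hydroxyl groups or from oxygen replacing nitrogen on the carbonyl carbon stays open. Ethylamino at this place would separate the two.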